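Adding a second methoxy to compound 3

A few compounds are considered here, and "the series" means these few. Any claim that something is new, unique, unknown or untested is made for them only; others in the source may bear on it.

Values in a functional assay on HT-29 cells (Homo sapiens) for antiproliferative activity, read by MTT assay, with a stated time of 72 h; a lower number here means a stronger inhibitor, a higher number a weaker inhibitor:
- compound 1 `CCCCCn1ccnc1-c1cc(OC)c(OC)c(OC)c1`: 60100 nM
- compound 2 `COc1cc(-c2nccn2-c2cccc(C)c2)cc(OC)c1OC`: 14600 nM
- compound 3 `COc1cccc(-n2ccnc2-c2cc(OC)c(OC)c(OC)c2)c1`: 18900 nM

Compound 3 shares the low end of these three numbers with the 3-methylphenyl compound, and the two cannot be separated: a 1.3-fold higher number from compound 2 to compound 3 (0.11 log units; within the scatter). Both stand clear of the pentyl compound, with a 4.1-fold lower number from compound 1 to compound 2 (0.61 log units; beyond the scatter) and a 3.2-fold lower number from compound 1 to compound 3 (0.50 log units; beyond the scatter).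

The next structure is compound 4 `COc1cc(OC)cc(-n2ccnc2-c2cc(OC)c(OC)c(OC)c2)c1`. The change is methoxy in place of hydrogen on an aromatic carbon, which is methoxy in place of hydrogen on an aromatic carbon, meta to a large group and meta to a methoxy group.

For the measured compounds named here, no measured step adds a group to this ring. The nearest evidence is the exchange of methyl for methoxy on the ring, which gave a 1.3-fold higher number from compound 2 to compound 3 (0.11 log units; within the scatter). The replacement of pentyl gave only modest steps, and it was a far larger change than this one. A small step in this assay is therefore expected, most likely within the scatter and, if anything, towards a lower number. The expected step is a 1.4-fold lower number from compound 3 to compound 4 (0.13 log units; within the scatter). Compound 4 is estimated at 14000 nM, with an expected range of 5000 nM to 40000 nM.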

Compound 4, half-maximal inhibitory concentration: 74500 nM
Estimate against measurement, compound 4: 5.3-fold (0.73 log units) below, and the stated range ends below it.
By their numbers in this assay, from the lowest: compounds 2 and 3 (each within the scatter of the next); then compounds 1 and 4 (each within the scatter of the next).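

In this assay, methoxy in place of hydrogen on this aromatic carbon, meta to a large group and meta to a methoxy group, is not a silent change: it gives a 3.9-fold higher number from compound 3 to compound 4 (0.60 log units; beyond the scatter). For the compounds shown here, the earlier evidence on this ring came only from an exchange at an already substituted carbon, methoxy in place of methyl, which gave a 1.3-fold higher number from compound 2 to compound 3 (0.11 log units; within the scatter) and could not be read as a change, so compound 4 provides the first step on this ring that lies beyond the scatter, and it runs towards weaker inhibition, opposite in direction to the replacement of pentyl in a 3.2-fold lower number from compound 1 to compound 3 (0.50 log units; beyond the scatter). The data at hand offer no measurement that accounts for this step.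

One step at one carbon cannot separate an effect of methoxy itself from an effect of placing any group there, so the same carbon carrying fluorine, hydroxy or an amine would be the informative comparison. On these data alone, whether the step recurs with a methyl group in place of the first methoxy, or holds in any readout other than this antiproliferative one, also remains open.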